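The compounds below may be only part of what the source reports. "The series", "measured", "known", "first", "only" and "open" are said of these compounds alone.

Three measured compounds share one core and differ only in the aryl group carried on a ring nitrogen. In a functional assay on MDA-MB-468 cells (Homo sapiens) for antiproliferative activity, read by MTT assay, with a stated time of 24 h (a higher number here means a weaker inhibitor, a lower number a stronger inhibitor), compound 1 `CNC(=O)c1ccccc1Oc1nc(Nc2ccc(Br)cc2)ncc1Br` gives 36600 nM. In this assay compound 3 `CNC(=O)c1ccccc1Oc1nc(Nc2cccc(C)c2)ncc1Br` gives 18600 nM. For compound 2 `CNC(=O)c1ccccc1Oc1nc(Nc2ccccc2F)ncc1Br` the same assay returns only a limit, > 50000 nM, and not a number (the limit of > 50000 nM in this assay, at which 1 of the 3 values shown sits). Where compound 3 stands is therefore told by two steps: the step of a 2.0-fold lower number from compound 1 to compound 3 (0.29 log units; within the scatter) stays within the scatter, so compound 1 and compound 3 cannot be told apart, while the step of an at least 2.6-fold lower number from compound 2 to compound 3 (0.42 log units; beyond the scatter) is at least modest and lies beyond the scatter.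

Compound 4 `CNC(=O)c1ccccc1Oc1nc(Nc2cccc(OC)c2)ncc1Br` differs from compound 3 in one place: methoxy in place of methyl on an aromatic carbon. Among the measured compounds shown here, both measured steps exchanged the whole aryl group on that nitrogen, and the one that ends at compound 3, a 2.0-fold lower number from compound 1 to compound 3 (0.29 log units; within the scatter), moved the number only within the scatter. The exchange of methyl for methoxy is a smaller change than either measured swap, so no movement beyond the scatter is expected in this assay. For compound 4 the expected step is a 1.2-fold lower number from compound 3 to compound 4 (0.07 log units; within the scatter). The estimate for compound 4 is 16000 nM, with a range from 6000 nM to 45000 nM.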

Compound 4, half-maximal inhibitory concentration: 17800 nM
Beside the measured number, compound 4's estimate is 1.1-fold (0.05 log units) below it; the measured number falls inside the stated range.
By their numbers in this assay, from the lowest: compounds 4, 3 and 1 (each within the scatter of the next, the first and the last beyond it). At a limit, above all of these: compound 2.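

Methoxy in place of methyl on this aromatic carbon, meta to a large group, is the first change here that keeps the phenyl ring on the nitrogen and alters only what it carries, and in this assay it leaves the number unchanged within the scatter: a 1.0-fold lower number from compound 3 to compound 4 (0.02 log units; within the scatter). Against the 4-bromophenyl group the picture shifts only slightly, since the step of a 2.1-fold lower number from compound 1 to compound 4 (0.31 log units; beyond the scatter) passes the scatter and is modest, yet compound 3 and compound 4 cannot be told apart, so this gives no ground for ranking methoxy over methyl. Compound 2 still has only a limit and not a number, which makes the step of an at least 2.8-fold lower number from compound 2 to compound 4 (0.44 log units; beyond the scatter) a floor rather than a measured size: the limit of > 50000 nM in this assay, at which 1 of the 4 values shown sits.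

The two groups compared at this carbon leave open whether any other group there could move the number beyond the scatter. A hydroxyl, an amine, a carboxylic acid or a longer chain such as ethoxy might behave differently, and the compounds shown cannot say whether any of them would.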